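From methoxy to trifluoromethoxy at the assay limit

The compounds below may be only part of what the source reports. "The series", "measured", "known", "first", "only" and "open" are said of these compounds alone.

Compound 1 `COc1ccc(NC(=O)c2cc(=O)[nH]c3cc(Br)ccc23)cc1` gives > 20000 nM
Compound 2 `O=C(Nc1ccc(F)cc1F)c1cc(=O)[nH]c2cc(Br)ccc12` gives > 20000 nM

In a functional assay on KYSE-70 cells for antiproliferative activity against KYSE-70 cell line (Homo sapiens), read by MTT assay, with a stated time of 72 h (a higher number here means a weaker inhibitor, a lower number a stronger inhibitor), compound 1 gives > 20000 nM as a limit of the assay, not a number. Compound 2 likewise gives > 20000 nM as a limit. Compound 1 thus stands at the limit of > 20000 nM in this assay, at which 2 of the 2 values shown sit, and has no exact number.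

Compound 3 `O=C(Nc1ccc(OC(F)(F)F)cc1)c1cc(=O)[nH]c2cc(Br)ccc12` carries trifluoromethyl in place of methyl on an oxygen on an aromatic ring. Going by the values given here, no measured step shows what such a change does in this assay, so no shift beyond the scatter is expected and no direction is favoured. The expected step is a number no higher from compound 1 to compound 3 (the limit leaves the size open) in size. The estimated value for compound 3 is 20000 nM (expected range 8000 nM to 40000 nM).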

Compound 3, half-maximal inhibitory concentration: > 20000 nM
Compound 3 gave a limit, no number; the forecaster's own chance of this, stated with the estimate: 70%; the middle value lies on the limit itself.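

No new step can be read from compound 1 to compound 3, since both results are limits of the assay, not numbers: the limit of > 20000 nM in this assay, at which 3 of the 3 values shown sit.

The compounds shown leave open which change to the shared core, if any, would give a measurable number in this assay.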